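The compounds below may be only part of what the source reports. "The series", "measured", "known", "first", "only" and "open" are said of these compounds alone.

Three compounds have been measured in a functional assay on HEK293 cells for agonist activity at Free fatty acid receptor 1 (Homo sapiens), read by fluorescence and calcium flux, with a stated time of 1 h; a higher number here means that more compound is needed for the effect, a lower number that less compound is needed:

Compound 1 `COc1ccc(F)c(-c2ncc(COc3cccc([C@@H](CC(=O)O)C4CC4)c3)cc2C2=CCCC2(C)C)c1`: 21.3 nM
Compound 2 `COc1ccc(F)c(-c2cnc(COc3cccc([C@@H](CC(=O)O)C4CC4)c3)nc2C2=CCCC2(C)C)c1`: 12.4 nM
Compound 3 `COc1ccc(F)c(-c2ncc(COc3cccc([C@@H](CC(=O)O)C4CC4)c3)nc2C2=CCCC2(C)C)c1`: 37 nM

Compound 3 carries the highest number of the three. Its gap to compound 1 lies within the scatter, so the two cannot be told apart; its gap to compound 2 lies beyond the scatter, and compound 2 needs less compound than compound 3. Compound 4 `COc1ccc(F)c(-c2ncc(COc3cccc([C@@H](CC(=O)O)C4CC4)c3)nc2N2CC3(CCC3)C2)c1` differs from compound 3 by a group of 7 heavy atoms (6 carbon, 1 nitrogen; one four-membered non-aromatic ring of carbon only, one four-membered non-aromatic ring with 1 hetero atom) in place of a group of 7 heavy atoms (7 carbon; one five-membered non-aromatic ring of carbon only), on an aromatic carbon. Among the compounds with values here, no measured pair in this set shows a change of this kind, so the size of the step cannot be read from the data. Compound 4 is expected to give 65 nM in this assay, with a range from 15 nM to 280 nM. The expected step of a 1.8-fold higher number from compound 3 to compound 4 (0.24 log units; within the scatter) is a modest rise in the number, only just beyond the scatter.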

Compound 4, half-maximal effective concentration: 4.5 nM
Compound 4: middle estimate off by 14-fold (1.16 log units), on the high side; the measured number lies below the stated range.
By their numbers in this assay, from the lowest: compound 4; then compounds 2, 1 and 3 (each within the scatter of the next, the first and the last beyond it).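

In this assay, within the data shown here, the step of an 8.2-fold lower number from compound 3 to compound 4 (0.91 log units; beyond the scatter) is the first view of a change at this position, since compounds 1, 2 and 3 all carry the 5,5-dimethylcyclopent-1-en-1-yl group. It shows that this aromatic carbon, next to the ring nitrogen, accepts a group joined through a ring nitrogen, with two four-membered rings, and that less compound is then needed for the effect. Nothing available explains this step.

Going by these compounds, whether the same exchange would give a similar step on the cores of compound 1 and compound 2 remains open. So does how a simpler ring amine such as pyrrolidine or morpholine would read at this position.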